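Linker shortening in hydroxamate series: compound 3 to compound 4

The source may hold more compounds than are shown below. What is called first, only, known or untested is meant among the compounds shown, and "the series" means these compounds.

Measured so far in a functional assay on CNE-2 cells (Homo sapiens) for inhibition, read by MTT assay, with a stated time of 72 h; a higher number here means a weaker inhibitor, a lower number a stronger inhibitor:
compound 1 `Nc1nc2cc(-c3nn(CC(=O)NO)c4ncnc(N)c34)ccc2o1` gives 12200 nM.
compound 2 `Nc1nc2cc(-c3nn(CCCC(=O)NO)c4ncnc(N)c34)ccc2o1` gives only a limit, > 50000 nM.
compound 3 `Nc1nc2cc(-c3nn(CCCCCCCCC(=O)NO)c4ncnc(N)c34)ccc2o1` gives 3240 nM.

Compound 3 holds the lowest of the two numbers given, with compound 1 next and beyond the scatter. Compound 4 `Nc1nc2cc(-c3nn(CCCCCCC(=O)NO)c4ncnc(N)c34)ccc2o1` differs from compound 3 by hydroxycarbamoyl in place of 2-(hydroxycarbamoyl)ethyl on a saturated chain carbon, six bonds along the chain from an aromatic nitrogen. Along the same chain the measured steps are an at least 4.0-fold higher number from compound 1 to compound 2 (0.61 log units; beyond the scatter) and an at least 15-fold lower number from compound 2 to compound 3 (1.18 log units; beyond the scatter), so the numbers do not move steadily with chain length; compound 2 sits at the limit (the limit of > 50000 nM in this assay, at which 1 of the 3 values shown sits). Since compound 4 lies between compound 2 and compound 3 in chain length, a modest rise is expected, a 1.9-fold higher number from compound 3 to compound 4 (0.27 log units; within the scatter). Compound 4 is estimated at 6000 nM, in the range 2000 nM to 30000 nM.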

Compound 4, half-maximal inhibitory concentration: 4360 nM
The estimate for compound 4 lay 1.4-fold (0.14 log units) above the measured number, and the stated range covers the measured number.
By their numbers in this assay, from the lowest: compounds 3 and 4 (each within the scatter of the next); then compound 1. At a limit, above all of these: compound 2.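

In this assay, the two longest chains cannot be told apart: a 1.3-fold higher number from compound 3 to compound 4 (0.13 log units; within the scatter). The shorter of these two chains keeps the whole advantage over the short chains, with an at least 11-fold lower number from compound 2 to compound 4 (1.05 log units; beyond the scatter) and a 2.8-fold lower number from compound 1 to compound 4 (0.45 log units; beyond the scatter). The comparison with compound 2 rests on a limit: the limit of > 50000 nM in this assay, at which 1 of the 4 values shown sits.

Going by these compounds, how the numbers run from the chain of compound 2 to that of compound 4 stays open. Also open, on these data alone, is whether a chain longer than that of compound 3, or a carboxylic acid in place of hydroxycarbamoyl, would keep these numbers.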